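Removing the ether side chain from a homodimeric chromone scaffold

This account rests on a few compounds, and the source may have more. Where it says the series, first, only, none or still open, it means among the compounds named here.

Three compounds sharing one core were measured in a functional assay on ACHN cells (Homo sapiens) for antiproliferative activity, read by XTT assay; a higher number here means a weaker inhibitor, a lower number a stronger inhibitor. Compound 1 `O=c1c(Cc2coc3cccc(OCC4CCCCC4)c3c2=O)coc2ccccc12` gives 4230 nM, compound 2 `CC(C)COc1cccc2occ(Cc3coc4ccccc4c3=O)c(=O)c12` gives 1460 nM, and compound 3 `CC(C)CCOc1cccc2occ(Cc3coc4ccccc4c3=O)c(=O)c12` gives 3960 nM. Compound 3 thus sits second highest of the three numbers: the step of a 1.1-fold lower number from compound 1 to compound 3 (0.03 log units; within the scatter) lies within the scatter, while the step of a 2.7-fold higher number from compound 2 to compound 3 (0.43 log units; beyond the scatter) is a modest one beyond the scatter. All three measured steps, a 2.9-fold lower number from compound 1 to compound 2 (0.46 log units; beyond the scatter), a 1.1-fold lower number from compound 1 to compound 3 (0.03 log units; within the scatter) and a 2.7-fold higher number from compound 2 to compound 3 (0.43 log units; beyond the scatter), only swap one alkyl group for another on the saturated chain carbon bound to the ring oxygen, and none of them moves the number by more than a modest amount.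

Compound 4 `O=c1c(Cc2coc3ccccc3c2=O)coc2ccccc12` makes a different kind of change: hydrogen in place of isopentyloxy on an aromatic carbon. Within the data shown here, no measured step removes the whole ether side chain, so the three alkyl swaps bear on it only indirectly, by showing that this part of the molecule changes the read-out modestly at best. The expected step is therefore a 1.3-fold higher number from compound 3 to compound 4 (0.10 log units; within the scatter), with wide uncertainty. Compound 4 is accordingly expected to give about 5000 nM, within a range from 1500 nM to 16000 nM.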

Compound 4, half-maximal inhibitory concentration: 510 nM
The estimate for compound 4 lay 9.8-fold (0.99 log units) above the measured number; measured number outside the range, below it.
By their numbers in this assay, from the lowest: compound 4; then compound 2; then compounds 3 and 1 (each within the scatter of the next).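

In this assay the aromatic carbon carrying hydrogen reads lower than it does with any of the ethers shown: hydrogen in place of isopentyloxy gives a 7.8-fold lower number from compound 3 to compound 4 (0.89 log units; beyond the scatter) and hydrogen in place of cyclohexylmethoxy gives an 8.3-fold lower number from compound 1 to compound 4 (0.92 log units; beyond the scatter) while hydrogen in place of isobutoxy gives a 2.9-fold lower number from compound 2 to compound 4 (0.46 log units; beyond the scatter) at the same position. Compound 4 is therefore the strongest inhibitor of the four, and none of the three ether side chains improves on the bare position. The alkyl swaps had compared ethers only with one another, so they could not show that each of these side chains, taken as a whole, raises the number here; the rise is not uniform, being smallest for the isobutoxy group of compound 2.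

From the compounds shown here alone, it remains open whether a smaller group on this aromatic carbon, such as methoxy, hydroxyl or an amine, would read as low as hydrogen or lower. Nothing measured here accounts for the lower number of compound 4.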